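Methoxy for chloro on the pendant phenyl

The compounds below may be only part of what the source reports. "The series", "measured", "known", "first", "only" and "open" are said of these compounds alone.

Measured compounds:
compound 1 `Cn1ccc2c(Oc3ccc(NC(=O)c4cc5cccnc5n(-c5ccccc5)c4=O)cc3)ccnc21` — 5030 nM in a functional assay on U-87MG ATCC cells for antiproliferative activity against U-87 MG (Homo sapiens), read by MTT assay, with a stated time of 72 h; on this read-out higher numbers stand for weaker inhibition and lower numbers for stronger inhibition
compound 2 `Cn1ccc2c(Oc3ccc(NC(=O)c4cc5cccnc5n(-c5ccc(Cl)cc5)c4=O)cc3)ccnc21` — "not determined" (no result reported) in this assay

Compound 2 stands without a number: in this assay it was not determined, so the unsubstituted compound 1 is the only anchor. Compound 3 `COc1ccc(-n2c(=O)c(C(=O)Nc3ccc(Oc4ccnc5c4ccn5C)cc3)cc3cccnc32)cc1` differs from compound 2 by methoxy in place of chloro on an aromatic carbon. Among the measured compounds shown here, no step between measured compounds is recorded, so neither size nor direction can be read from the series; a shift within the usual scatter is as plausible as any. Compound 3 is estimated at 4000 nM, expected between 1200 nM and 15000 nM, close to what compound 1 shows.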

Compound 3, half-maximal inhibitory concentration: 5150 nM
The estimate for compound 3 lay 1.3-fold (0.11 log units) below the measured number; low and high end bracket the measured number.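

In this assay, methoxy in place of hydrogen on the pendant phenyl, para to a large group, gives a 1.0-fold higher number from compound 1 to compound 3 (0.01 log units; within the scatter) and so leaves the read-out of the core of compound 1 undisturbed at this position. The step from compound 2 to compound 3 cannot be read, as compound 2 has no number. No data on hand offer an account of this result.

As far as these compounds go, whether chloro reads like methoxy here remains open. So does whether an amine or a carboxylic acid on this carbon would move the number beyond the scatter.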